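The source may hold more compounds than are shown below. What is called first, only, known or untested is meant among the compounds shown, and "the series" means these compounds.

Among the compounds with values here, compound 1 `O=C(NCCCOc1cccc(CN2CCCCC2)c1)Nc1ccc(C(F)(F)F)cc1` gives 1700 nM in an assay on isolated protein for inhibition of histamine H2 receptor (Cavia porcellus) (on this read-out lower numbers stand for tighter binding and higher numbers for weaker binding), the second highest of the three numbers measured so far; the closest value is that of compound 2 `CC(C)(C)NC(=O)NCCCOc1cccc(CN2CCCCC2)c1` at 2090 nM, and the furthest that of compound 3 `CCCCNC(=O)NCCCOc1cccc(CN2CCCCC2)c1` at 81.3 nM. The step of a 1.2-fold higher number from compound 1 to compound 2 (0.09 log units; within the scatter) stays within the scatter, whereas a 21-fold lower number from compound 1 to compound 3 (1.32 log units; beyond the scatter) and a 26-fold lower number from compound 2 to compound 3 (1.41 log units; beyond the scatter) are both large. Compound 4 `CCCNC(=O)NCCCOc1cccc(CN2CCCCC2)c1` differs from compound 1 by propyl in place of 4-(trifluoromethyl)phenyl on an amide-type nitrogen. Because a 21-fold lower number from compound 1 to compound 3 (1.32 log units; beyond the scatter) likewise exchanges the same leaving group for an unbranched chain, propyl and butyl being both unbranched chains, a drop of comparable size, perhaps a little smaller, is expected for compound 4, namely a 14-fold lower number from compound 1 to compound 4 (1.15 log units; beyond the scatter). On this basis compound 4 is estimated at 120 nM in this assay, with a range of 40 nM to 400 nM.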

Compound 4, dissociation constant: 97.7 nM
Compound 4: middle estimate off by 1.2-fold (0.09 log units), on the high side; low and high end bracket the measured number.
By their numbers in this assay, from the lowest: compounds 3 and 4 (each within the scatter of the next); then compounds 1 and 2 (each within the scatter of the next).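

In this assay, the step between butyl and propyl on the amide-type nitrogen gives a 1.2-fold higher number from compound 3 to compound 4 (0.08 log units; within the scatter), so these two unbranched chains cannot be told apart here. Propyl also gives a 17-fold lower number from compound 1 to compound 4 (1.24 log units; beyond the scatter) and a 21-fold lower number from compound 2 to compound 4 (1.33 log units; beyond the scatter), so among these four compounds both unbranched chains stand well apart from 4-(trifluoromethyl)phenyl and tert-butyl. Nothing available explains this difference. From the compounds shown here alone, it remains open whether ethyl or a longer chain such as hexyl would match propyl and butyl. Going by these compounds, it also remains open whether branched isopropyl would side with tert-butyl.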